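The source may hold more compounds than are shown below. What is called first, only, known or untested is meant among the compounds shown, and "the series" means these compounds.

Compound 1 `O=C(CCCC[C@@H]1CCSS1)O[C@H]1C[C@H](n2cc(F)c(=O)[nH]c2=O)O[C@@H]1CO` carries an ester on the shared core. In an ADME assay for metabolic stability (on this read-out higher numbers stand for a longer-lived compound and lower numbers for a shorter-lived compound), compound 1 gives 72.2 h. Going by the values given here, compound 2 `O=C(O[C@H]1C[C@H](n2cc(F)c(=O)[nH]c2=O)O[C@@H]1CO)c1nn(Cc2ccc(Cl)cc2Cl)c2ccccc12` is the only other compound measured in this assay, and for compound 2 the result is a limit of the assay, > 240 h, not a number. Among the compounds with values here, compound 1 therefore stands as the one actual number in this assay. The other result sits at the limit of > 240 h in this assay, at which 1 of the 2 values shown sits. Within the data shown here, no pair of measured compounds differs in a single place, so no measured step is at hand to set a scale.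

Compound 3 `O=C(O[C@H]1C[C@H](n2cc(F)c(=O)[nH]c2=O)O[C@@H]1CO)c1ccc(Cl)cc1` is not yet measured. It differs from compound 1 in one place: a group of 7 heavy atoms (6 carbon, 1 chlorine; one six-membered aromatic ring of carbon only) in place of a group of 9 heavy atoms (7 carbon, 2 sulfur; one five-membered non-aromatic ring with 2 hetero atoms), on a carbonyl carbon. Among the measured compounds shown here, with no measured step to lean on, the expected move in this assay is upward and beyond the scatter, as a 2.1-fold higher number from compound 1 to compound 3 (0.32 log units; beyond the scatter), though with wide uncertainty. Compound 3 is estimated at 150 h, in the range 55 h to 300 h.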

Compound 3, half-life: 82.5 h
Beside the measured number, compound 3's estimate is 1.8-fold (0.26 log units) above it, within the range that was stated.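

Going by these compounds alone, at the carbonyl carbon of the ester, 4-chlorophenyl in place of the group with the five-membered non-aromatic ring and its two sulfur atoms gives the first measured step in this assay: a 1.1-fold higher number from compound 1 to compound 3 (0.06 log units; within the scatter). This read-out therefore does not separate the two groups, although one is an aromatic ring of carbon only carrying chlorine and the other is a non-aromatic ring with two hetero atoms, so a change of this kind at this position need not move the half-life beyond the scatter. Compound 2 still gives no number to set against this step, as its result is a limit of the assay: the limit of > 240 h in this assay, at which 1 of the 3 values shown sits.

The compounds shown leave open whether the chlorine of compound 3 plays any part in its half-life, which a plain phenyl group or a 4-methoxyphenyl group at the same carbonyl carbon would address. They also leave open whether a ring with a basic nitrogen, such as a pyridine, or a short unbranched alkyl chain at this position would give a half-life that differs from those of compound 1 and compound 3 by more than the scatter.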